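The compounds below may be only part of what the source reports. "The series", "measured", "known", "first", "only" and "open" are said of these compounds alone.

Compound 3 `O=C(Nc1cccc(S(=O)(=O)C2CCCC2)c1)c1cccnc1N1CCC2(CC1)CC2` gives > 399 mL.min-1.g-1 in an ADME assay on microsomes from liver (Mus musculus) for metabolic stability, read by LC-MS, with a stated time of 40 min, tested at 0.5 uM (on this read-out higher numbers stand for fast clearance and lower numbers for slow clearance), and this is a limit, not a number. Compound 1 `O=C(Nc1cccc(S(=O)(=O)C2CCCC2)c1)c1cccnc1N1CCC(F)(F)CC1` also gives only a limit in this assay, at > 399 mL.min-1.g-1. Compound 2 `CC1(C)CCN(c2ncccc2C(=O)Nc2cccc(S(=O)(=O)C3CCCC3)c2)CC1` likewise gives only a limit, at > 399 mL.min-1.g-1.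

Compound 4 `O=C(Nc1cccc(S(=O)(=O)C2CCCC2)c1)c1cccnc1N1CCCCC1` differs from compound 3 in one place: a group of 6 heavy atoms (5 carbon, 1 nitrogen; one six-membered non-aromatic ring with 1 hetero atom) in place of a group of 8 heavy atoms (7 carbon, 1 nitrogen; one three-membered non-aromatic ring of carbon only, one six-membered non-aromatic ring with 1 hetero atom), on an aromatic carbon. Here piperidin-1-yl enters on an aromatic carbon of a six-membered aromatic ring with 1 nitrogen, next to the ring nitrogen and ortho to a large group.

The measured steps that bear on this change are those among the groups at the same place: a step that the two limits leave unreadable from compound 1 to compound 2, a step that the two limits leave unreadable from compound 1 to compound 3 and a step that the two limits leave unreadable from compound 2 to compound 3. None of the three has a size that can be read, so they give neither a direction nor a magnitude for the new step.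

For compound 4 a further result at the limit is expected because of the limit of > 399 mL.min-1.g-1 in this assay, at which 3 of the 3 values shown sit. The step estimated here is a step that the limit leaves unreadable from compound 3 to compound 4, with no direction expected and no size beyond the scatter. The estimate for compound 4 is 420 mL.min-1.g-1, with an expected range from 220 mL.min-1.g-1 to 800 mL.min-1.g-1.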

Compound 4, intrinsic clearance in microsomes: > 399 mL.min-1.g-1
Compound 4: only a limit was reported; the forecaster's own chance of this, stated with the estimate: 75%; the middle value is on the limit's open side.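

Compound 4 gives only a limit in this assay, at > 399 mL.min-1.g-1. No step between compound 4 and compounds 1, 2 or 3 can be read, since all of them sit at the same limit: the limit of > 399 mL.min-1.g-1 in this assay, at which 4 of the 4 values shown sit.

From the compounds shown here alone, whether the groups at this place differ at all in clearance, and in which order, remains open.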